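The compounds below may be only part of what the source reports. "The series", "measured", "known", "first", "only" and "open" are said of these compounds alone.

Working notes on the thiazole series in a functional assay (aorta) with Rattus norvegicus as the target; a lower number here means that less compound is needed, a higher number that more compound is needed for the effect.

Compound 1 `COc1ccc(-c2nc(N=C(N)N)sc2-c2ccc(OC)cc2)cc1` carries a guanidine on the shared core and in this assay gives 2 uM. Compound 2 `C/N=C(/NC)Nc1nc(-c2ccc(OC)cc2)c(-c2ccc(OC)cc2)s1` gives 2.4 uM, which is the second highest of the three numbers: the step of a 1.2-fold higher number from compound 1 to compound 2 (0.08 log units; within the scatter) is within the scatter, so compound 1 and compound 2 are not separated here. Compound 3 `COc1ccc(-c2nc(CN)sc2-c2ccc(OC)cc2)cc1` gives 7.7 uM; the steps of a 3.9-fold higher number from compound 1 to compound 3 (0.59 log units; beyond the scatter) and a 3.2-fold higher number from compound 2 to compound 3 (0.51 log units; beyond the scatter) are modest but beyond the scatter.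

Compound 4 `COc1ccc(-c2nc(CNC(=O)N3CCOCC3)sc2-c2ccc(OC)cc2)cc1` has not been measured in this assay. From compound 2 it differs as follows: a group of 10 heavy atoms (6 carbon, 2 nitrogen, 2 oxygen; one six-membered non-aromatic ring with 2 hetero atoms) in place of a group of 6 heavy atoms (3 carbon, 3 nitrogen; no ring), on an aromatic carbon. Among the measured compounds shown here, the one measured step that bears on this is the removal of the guanidine-type group, a 3.2-fold higher number from compound 2 to compound 3 (0.51 log units; beyond the scatter), where a group of 2 heavy atoms took its place and the number rose. For the measured compounds named here, compound 4 likewise loses that group, but what enters is larger and carries a carbonyl and the morpholine ring rather than a bare aminomethyl, and no measured pair informs on that part. The expectation is therefore a modest rise in the number, a 3.3-fold higher number from compound 2 to compound 4 (0.52 log units; beyond the scatter), of about the size seen for compound 3, with wide uncertainty.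

Compound 4 is estimated at 8 uM, range 3 uM to 25 uM.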

Compound 4, concentration for half-maximal effect: 12 uM
Compound 4: middle estimate off by 1.5-fold (0.18 log units), on the low side, within the range that was stated.
By their numbers in this assay, from the lowest: compounds 1 and 2 (each within the scatter of the next); then compounds 3 and 4 (each within the scatter of the next).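

In this assay, placing (morpholin-4-yl)carbonyl on the amine nitrogen of the aminomethyl group gives a 1.6-fold higher number from compound 3 to compound 4 (0.19 log units; within the scatter) and so does not separate the larger group from the bare aminomethyl group at this position on the aromatic carbon. Among the compounds shown here, the separation from the guanidine-type groups stays beyond the scatter with this larger group in place, as a 6.0-fold higher number from compound 1 to compound 4 (0.78 log units; beyond the scatter) and a 5.0-fold higher number from compound 2 to compound 4 (0.70 log units; beyond the scatter) show, so among the four compounds those with guanidine-type groups fall on one side and those with a methylene-linked nitrogen on the other, with no compound going against this. No measurement on hand accounts for this split and the split remains a description of these four compounds only.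

The compounds shown leave open whether the carbonyl or the morpholine ring contributes anything separately, which an acetyl group or a piperidine ring on the same amine nitrogen would address. On these data alone, it also remains open where a carboxylic acid or a longer aminoalkyl chain at this position would fall relative to these two groups of compounds.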